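Dimethylamino for trifluoromethoxy on the shared core

This account rests on a few compounds, and the source may have more. Where it says the series, first, only, none or still open, it means among the compounds named here.

Of the compounds shown here, three of one shared core have been measured in an ADME assay on Raji cells (Homo sapiens) for cytotoxicity, with a stated time of 72 h; a higher number here means that more compound is needed for the effect, a lower number that less compound is needed. Compound 1 `Cc1cc(NC(=O)Nc2cccc(Cl)c2)c2ccccc2n1` gives 18000 nM. Compound 2 `Cc1cc(NC(=O)Nc2cccc(C(N)=O)c2)c2ccccc2n1` reaches only the limit > 25000 nM, which is a limit of this assay, not a number (the limit of > 25000 nM in this assay, at which 1 of the 3 values shown sits). Compound 3 `Cc1cc(NC(=O)Nc2cccc(OC(F)(F)F)c2)c2ccccc2n1` gives 9000 nM; the step of a 2.0-fold lower number from compound 1 to compound 3 (0.30 log units; within the scatter) sits within the scatter, while the step of an at least 2.7-fold lower number from compound 2 to compound 3 (0.44 log units; beyond the scatter) goes beyond it. Compound 4 `Cc1cc(NC(=O)Nc2cccc(N(C)C)c2)c2ccccc2n1` is not yet measured; it differs from compound 3 by dimethylamino in place of trifluoromethoxy on an aromatic carbon. Among the measured compounds shown here, no measured step swaps these two groups, and the swaps that exist span an at least 1.3-fold higher number from compound 1 to compound 2 (0.14 log units; that floor lies within the scatter) up to the step from compound 2. Compound 4 is therefore expected to give 15000 nM, between 6000 nM and 40000 nM, an estimated step of a 1.7-fold higher number from compound 3 to compound 4 (0.22 log units; within the scatter) in this assay.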

Compound 4, half-maximal effective concentration: > 25000 nM
Compound 4 was reported as a limit (the forecaster's own chance of this, stated with the estimate: 30%); middle value at least 1.6-fold (0.22 log units) from the limit.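

Dimethylamino in place of trifluoromethoxy gives an at least 2.7-fold higher number from compound 3 to compound 4 (0.44 log units; beyond the scatter) in this assay, so a swap at this position now goes beyond the scatter with a group other than carbamoyl. Against chloro, dimethylamino gives an at least 1.3-fold higher number from compound 1 to compound 4 (0.14 log units; that floor lies within the scatter), a floor that does not separate the two compounds. The value of compound 4 is a limit, not a number: the limit of > 25000 nM in this assay, at which 2 of the 4 values shown sit.

The step between compound 2 and compound 4 cannot be read. Going by these compounds, whether a primary amine or a methoxy group at this position would stay close to compound 3 remains open.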